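Cytotoxicity notes: trifluoroethyl analogue of the series

The source may hold more compounds than are shown below. What is called first, only, known or untested is meant among the compounds shown, and "the series" means these compounds.

The series shares the core shown in compound 1 `O=c1[nH]c(=O)n(C2C[C@@H](O)[C@@H](CO)O2)nc1/C=C(\F)Br` and compound 2 `CS/C=C/c1nn(C2C[C@@H](O)[C@@H](CO)O2)c(=O)[nH]c1=O`, differing only in the group on an aromatic carbon. Within the data shown here, in a functional assay on Vero cells (Chlorocebus sabaeus) for cytotoxicity (on this read-out higher numbers stand for weaker inhibition and lower numbers for stronger inhibition), compound 2 gives 420 ug/mL, the only number so far. For compound 1 the result in this assay is the limit > 500 ug/mL, not a number. Among the measured compounds shown here, the single measured step, an at least 1.1-fold lower number from compound 1 to compound 2 (0.07 log units; that floor lies within the scatter), rests on the limit of > 500 ug/mL in this assay, at which 1 of the 2 values shown sits, and says no more than that both compounds inhibit weakly.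

Compound 3 `O=c1[nH]c(=O)n(C2C[C@@H](O)[C@@H](CO)O2)nc1CC(F)(F)F` is the next analogue: 2,2,2-trifluoroethyl in place of 2-(methylsulfanyl)ethenyl on an aromatic carbon. The new group sits next to the ring nitrogen. For the measured compounds named here, the one measured step bears on this change only loosely, as it too swaps the group on that aromatic carbon; it stayed within the scatter. No step beyond the scatter is therefore expected in this assay, in either direction, and the result may again be a limit. Compound 3 is estimated at 450 ug/mL, between 200 ug/mL and 1000 ug/mL, which means an expected step of a 1.1-fold higher number from compound 2 to compound 3 (0.03 log units; within the scatter).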

Compound 3, concentration for 50% inhibition: > 500 ug/mL
Compound 3 was reported as a limit; the forecaster's own chance of this, stated with the estimate: 50%; middle value at least 1.1-fold (0.04 log units) away from the limit.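

Replacing 2-(methylsulfanyl)ethenyl with 2,2,2-trifluoroethyl on this aromatic carbon gives an at least 1.1-fold higher number from compound 2 to compound 3 (0.07 log units; that floor lies within the scatter), so no direction can be assigned to this change in this assay. Compound 3 carries a group without the double bond outside aromatic rings found in 2-(methylsulfanyl)ethenyl, and its result is also a limit, > 500 ug/mL. The step between compound 1 and compound 3 cannot be read, and the results at this position now gather at a single limit: the limit of > 500 ug/mL in this assay, at which 2 of the 3 values shown sit.

The compounds shown leave open whether any group on this aromatic carbon can bring the number in this assay down by a step beyond the scatter, as all three groups here are open chains of similar heavy-atom count, and an amine, a carboxylic acid, a longer alkyl chain or a phenyl ring would test that more widely. They also leave open whether the change from 2-(methylsulfanyl)ethenyl to 2,2,2-trifluoroethyl has any readable effect at all, given that the only readable floor for it rests on a limit.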